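Chloro in Place of Iodo: An Expected Small Step

This account rests on a few compounds, and the source may have more. Where it says the series, first, only, none or still open, it means among the compounds named here.

Of the compounds shown here, two have been measured in a toxicity assay on the whole organism (P388 cells) for cytotoxicity, with Mus musculus as the target, with a stated time of 9 days, at a dose of 40 mg/kg by the intraperitoneal route; on this read-out higher numbers stand for a weaker effect at the one dose given and lower numbers for a stronger effect. Compound 1 `CN(C)/N=N\c1ccnc2ccc(Br)cc12` gives -3.5% in this assay. Compound 2 `CN(C)/N=N\c1ccnc2cc(I)ccc12` gives 5.7% in this assay; the two numbers lie within the usual scatter of each other, so neither can be set above the other. Compound 3 `CN(C)/N=N\c1ccnc2cc(Cl)ccc12` carries chloro in place of iodo on an aromatic carbon. For the measured compounds named here, with no step yet known, the change is expected to move this assay by no more than the scatter, in no particular direction. Compound 3 is therefore expected to give about 3% in this assay, between -15% and 20%; this expected step is a number 2.7 percentage points lower from compound 2 to compound 3 (within the scatter).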

Compound 3, a percentage reported as activity, at one dose (the size of the read-out at that dose, not a potency): -22.6%
For compound 3 the middle estimate is 25.6 percentage points above the measured one; the measured number lies below the stated range.
By their numbers in this assay, from the lowest: compound 3; then compounds 1 and 2 (each within the scatter of the next).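

Chloro in place of iodo on this aromatic carbon gives a number 28.3 percentage points lower from compound 2 to compound 3 (beyond the scatter) in this assay, a stronger effect at the one dose given. The two earlier compounds could not be set apart, whereas this exchange of one heavy atom for another shows that the read-out responds to what this position carries. Nothing available bears on why the step arises.

Going by these compounds, whether an amine or a methoxy group at this position would shift the read-out remains open, as does whether chloro in place of iodo elsewhere on the shared core would give a similar step.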